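A few compounds are considered here, and "the series" means these few. Any claim that something is new, unique, unknown or untested is made for them only; others in the source may bear on it.

In an ADME assay on L929 cells (Mus musculus) for cytotoxicity, read by resazurin assay, with a stated time of 96 h (on this read-out lower numbers stand for higher toxicity in this test and higher numbers for lower toxicity in this test), compound 1 `CC(=O)Nc1ccc(OC/C(=N\NC(N)=S)c2ccc(Br)cc2)cc1` gives 94900 nM. Compound 2 `NC(=S)N/N=C(\COc1ccc(I)cc1)c1ccc(Br)cc1` gives < 20400 nM, and this is a limit of the assay, not an exact number. Going by these compounds, compound 2 therefore stands on the more toxic side of compound 1, but its true value is unknown.

The next structure is compound 3 `NC(=S)N/N=C(\COc1ccc(-c2ccccc2)cc1)c1ccc(Br)cc1`, where phenyl takes the place of iodo on an aromatic carbon, para to a large group: phenyl in place of iodo on an aromatic carbon. Going by the values given here, the only measured step that bears on this change is an at least 4.6-fold lower number from compound 1 to compound 2 (0.66 log units; beyond the scatter), where iodo took the place of acetamido on an aromatic carbon. Among the compounds with values here, that step shows a clear move towards lower numbers, but no measured step runs from iodo to phenyl, so it cannot fix the size of this one. The safest expectation is that compound 3 stays close to compound 2, with no step beyond the scatter in this assay. The estimate means an expected step that the limit leaves unreadable from compound 2 to compound 3. Compound 3 is expected to give about 14000 nM, with an estimated range from 5000 nM to 40000 nM.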

Compound 3, half-maximal cytotoxic concentration: 90800 nM
The estimate for compound 3 lay 6.5-fold (0.81 log units) below the measured number, outside the stated range (above it).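

In this assay, the earlier pair showed only that iodo on this aromatic carbon, in place of acetamido, goes with a lower number; with phenyl on the same carbon, the result is an at least 4.4-fold higher number from compound 2 to compound 3 (0.64 log units; beyond the scatter). Phenyl and acetamido read alike at this place, with a 1.0-fold lower number from compound 1 to compound 3 (0.02 log units; within the scatter), so the loss of acetamido alone does not bring the number down, and among these three compounds only iodo stands apart. Compound 2 holds a limit and not an exact number, so the true size of the step from iodo to phenyl cannot be read: the limit of < 20400 nM in this assay, at which 1 of the 3 values shown sits.

The compounds shown leave open whether the low number belongs to iodo alone or to halogens on this carbon more widely, and a chloro or fluoro group in the same place would speak to that question. They also do not tell how an amine or a carboxylic acid on this carbon would read, or whether the same order of groups would hold on a core with something other than bromo on its second aromatic ring.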